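The compounds below may be only part of what the source reports. "The series", "measured", "known", "first", "only" and "open" are said of these compounds alone.

Measured in a functional assay on B16 cells (Mus musculus) for inhibition; a lower number here means a stronger inhibitor, a higher number a weaker inhibitor:
- compound 1 `COc1cc(/C=C/C(=O)c2cccc(NC(=O)c3c(Cl)cccc3Cl)c2)ccc1O` gives 1.58 ug/mL
- compound 2 `COc1cc(/C=C/C(=O)c2cccc(NC(=O)c3cccs3)c2)ccc1O` gives 6.93 ug/mL
- compound 3 `COc1cc(/C=C/C(=O)c2cccc(NC(=O)c3ccc(Cl)cc3Cl)c2)ccc1O` gives 12.8 ug/mL

Compound 3 stands with the highest number of the three: the step of an 8.1-fold higher number from compound 1 to compound 3 (0.91 log units; beyond the scatter) lies beyond the scatter, while a 1.8-fold higher number from compound 2 to compound 3 (0.27 log units; within the scatter) lies within it. Compound 4 `COc1cc(/C=C/C(=O)c2cccc(NC(C)=O)c2)ccc1O` is not yet measured; it differs from compound 3 by methyl in place of 2,4-dichlorophenyl on a carbonyl carbon. Among the compounds with values here, the steps that bear on this place, a 4.4-fold higher number from compound 1 to compound 2 (0.64 log units; beyond the scatter) and an 8.1-fold higher number from compound 1 to compound 3 (0.91 log units; beyond the scatter), show that what sits on this carbonyl carbon moves this assay by modest amounts. Nothing measured here carries a methyl at that place, so the direction rests on analogy alone. The expected step is a 1.7-fold higher number from compound 3 to compound 4 (0.24 log units; within the scatter), a modest rise in the number. Compound 4 is estimated at 22 ug/mL, within 7 ug/mL to 65 ug/mL.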

Compound 4, half-maximal inhibitory concentration: 3.62 ug/mL
The estimate for compound 4 lay 6.1-fold (0.78 log units) above the measured number, and the stated range ends above it.
By their numbers in this assay, from the lowest: compound 1; then compounds 4, 2 and 3 (each within the scatter of the next, the first and the last beyond it).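

In this assay a ring on this carbonyl carbon proves unnecessary for a number in this range: methyl gives a 3.5-fold lower number from compound 3 to compound 4 (0.55 log units; beyond the scatter) and a 1.9-fold lower number from compound 2 to compound 4 (0.28 log units; within the scatter), while a 2.3-fold higher number from compound 1 to compound 4 (0.36 log units; beyond the scatter) keeps the 2,6-dichlorophenyl group the better of the two. Methyl thus falls between the two dichlorophenyl groups, so an aromatic ring at this place does not by itself move the number one way. Nothing available accounts for this order. Open, going by these compounds, is how a longer chain, an amine or a carboxylic acid on this carbonyl carbon would compare with methyl.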